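The source may hold more compounds than are shown below. What is called first, only, known or untested is meant among the compounds shown, and "the series" means these compounds.

Compound 1 `NS(=O)(=O)c1ccc(N2N=C(c3ccccc3)CC2c2ccccc2F)cc1`, compound 2 `NS(=O)(=O)c1ccc(N2N=C(c3ccccc3)CC2c2ccccc2Cl)cc1` and compound 3 `Cc1ccccc1C1CC(c2ccc(OCc3ccccc3)cc2)=NN1c1ccc(S(N)(=O)=O)cc1` share one core and have each been run in an ADME assay on BHK-21 cells (Mesocricetus auratus) for cytotoxicity, read by MTT assay, with a stated time of 72 h; on this read-out lower numbers stand for higher toxicity in this test and higher numbers for lower toxicity in this test. Compound 1 gives 21000 nM, compound 2 gives 13000 nM, and compound 3 gives 20000 nM. Among the measured compounds shown here, the single one-point step recorded among them, a 1.6-fold lower number from compound 1 to compound 2 (0.21 log units; within the scatter), stays within the scatter. On the three numbers compound 3 stands second highest, closest to compound 1 and furthest from compound 2, with both gaps inside the scatter.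

Compound 4 `Cc1ccccc1C1CC(c2ccccc2)=NN1c1ccc(S(N)(=O)=O)cc1` differs from compound 3 by hydrogen in place of benzyloxy on an aromatic carbon. For the measured compounds named here, no measured step bears directly on this change: the only recorded step concerns chloro in place of fluoro on an aromatic carbon, and it moved nothing beyond the scatter. With no measured comparison pointing either way, the expectation in this assay is a step of no clear direction and no size beyond the scatter. Compound 4 is therefore estimated at 22000 nM, within a range from 9000 nM to 55000 nM. The step this estimate implies is a 1.1-fold higher number from compound 3 to compound 4 (0.04 log units; within the scatter).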

Compound 4, half-maximal cytotoxic concentration: 14000 nM
The estimate for compound 4 lay 1.6-fold (0.20 log units) above the measured number, and the stated range covers the measured number.
By their numbers in this assay, from the lowest: compounds 2, 4, 3 and 1 (each within the scatter of the next).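

Taking away the benzyloxy group, with its 8 heavy atoms and its aromatic ring, from the place para to a large group gives a 1.4-fold lower number from compound 3 to compound 4 (0.15 log units; within the scatter), so in this assay this whole group goes without a shift beyond the scatter. Methyl in place of a halogen on an aromatic carbon behaves the same way, with a 1.1-fold higher number from compound 2 to compound 4 (0.03 log units; within the scatter) for chloro and a 1.5-fold lower number from compound 1 to compound 4 (0.18 log units; within the scatter) for fluoro, which extends the flat picture from the halogen pair to a third group. Nothing available gives a reason for these small steps.

On these data alone, whether an amine or a carboxylic acid at the place of the benzyloxy group would move the number beyond the scatter stays open. So does whether benzyloxy would leave the number unchanged alongside fluoro or chloro rather than methyl.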